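Fluoro for Hydrogen: Expecting Little Change in Cytotoxicity

The source may report more compounds than this note shows. Statements on the series, on what has been measured and on what is new or still open speak of the compounds shown alone.

Compound 1, `Cc1nnc(SCC(=O)N/N=c2/scc(-c3ccccc3)n2-c2ccccc2)s1`, was tested in a functional assay on C6 cells (Rattus norvegicus) for cytotoxicity, read by MTT assay, with a stated time of 24 h, tested at 50 ug/mL (on this read-out higher numbers stand for a weaker effect at the one concentration tested and lower numbers for a stronger effect), and gives 63.9%. Of the two compounds measured, compound 1 stands highest; the other, compound 2, `O=C(CSc1nnnn1-c1ccccc1)N/N=c1/scc(-c2ccc(Br)cc2)n1-c1ccccc1`, gives 32% in this assay, a gap beyond the usual scatter. These two differ in several places at once, so nothing further is drawn from them. Compound 3, `Cc1nnc(SCC(=O)N/N=c2/scc(-c3ccc(F)cc3)n2-c2ccccc2)s1`, has not yet been measured. It differs from compound 1 only by fluoro in place of hydrogen on an aromatic carbon. For the measured compounds named here, with no single-change step to lean on, the move to compound 3 is expected to be small, in no set direction, and within the scatter, estimated as a number 3.9 percentage points lower from compound 1 to compound 3 (within the scatter). Compound 3 is therefore estimated at 60%, within 45% to 75%.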

Compound 3, a percentage reported as activity, at one concentration (the size of the read-out at that concentration, not a potency): 37.4%
Beside the measured number, compound 3's estimate is 22.6 percentage points above it, and the stated range ends above it.
By their numbers in this assay, from the lowest: compounds 2 and 3 (each within the scatter of the next); then compound 1.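

In this assay, the change from phenyl to 4-fluorophenyl reads as a number 26.5 percentage points lower from compound 1 to compound 3 (beyond the scatter), a shift towards a stronger effect. This position, para to a large group, therefore responds to a swap of a single atom, which the first two compounds, differing in several places at once, could not show. Nothing available explains why the step takes this direction or size. On these data alone, whether a chloro, a methoxy or an amine at this same place would also strengthen the effect remains open.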